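From 2-chlorobenzyl to 2-bromobenzyl: a halogen exchange

The source may hold more compounds than are shown below. What is called first, only, known or untested is meant among the compounds shown, and "the series" means these compounds.

In a functional assay on HeLa cells (Homo sapiens) for antiproliferative activity, read by MTT assay, with a stated time of 48 h (a higher number here means a weaker inhibitor, a lower number a stronger inhibitor), compound 1 `Brc1cccc(CSc2nnc(-c3cnccn3)o2)c1` gives 30300 nM as a measured number. Compound 2 `Clc1ccccc1CSc1nnc(-c2cnccn2)n1-c1ccccc1` has only a limit there, > 50000 nM, and not a number. Compound 3 `Brc1ccccc1CSc1nnc(-c2cnccn2)n1-c1ccccc1` carries bromo in place of chloro on an aromatic carbon, ortho to a large group (bromo in place of chloro on an aromatic carbon). For the measured compounds named here, no measured pair shows this change, so the expected step of an at least 1.1-fold lower number from compound 2 to compound 3 (0.04 log units; that floor lies within the scatter) in this assay is none beyond the scatter, with neither direction favoured. Compound 3 is estimated at 45000 nM with 20000 nM to 100000 nM as the expected range.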

Compound 3, half-maximal inhibitory concentration: > 50000 nM
Compound 3 gave a limit, no number; the forecaster's own chance of this, stated with the estimate: 60%; middle value at least 1.1-fold (0.04 log units) away from the limit.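

Compound 2 and compound 3 both give only a limit in this assay, and no step between them can be read: the limit of > 50000 nM in this assay, at which 2 of the 3 values shown sit.

The compounds shown leave open whether bromo in place of chloro changes the antiproliferative activity at all.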